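This account rests on a few compounds, and the source may have more. Where it says the series, first, only, none or still open, it means among the compounds named here.

Measured in a functional assay on MIA PaCa-2 cells (Homo sapiens) for antiproliferative activity, read by MTT assay, with a stated time of 72 h; on this read-out lower numbers stand for stronger inhibition and higher numbers for weaker inhibition:
- compound 1 `COc1cccc(/C=N/NC(=S)Nc2ccccc2)c1O`: 2500 nM
- compound 2 `Oc1ccccc1/C=N/NC(=S)Nc1ccccc1`: 2400 nM

For the measured compounds named here, only two compounds have numbers so far, and compound 1 stands level with compound 2. Going by the values given here, the single measured step between them, a 1.0-fold lower number from compound 1 to compound 2 (0.02 log units; within the scatter), puts hydrogen in place of methoxy on an aromatic carbon and stays within the scatter.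

Compound 3 `COc1cccc(/C=N/NC(N)=S)c1O` keeps the core of compound 1 but differs elsewhere, with hydrogen in place of phenyl on an amide-type nitrogen. The measured step, a 1.0-fold lower number from compound 1 to compound 2 (0.02 log units; within the scatter), concerns another group at another place, so it says little about this change. Among the compounds with values here, no measured pair tests the loss of the phenyl, which leaves the direction a matter of judgement. Removing a whole ring is a larger edit than the methoxy swap, so a moderate loss of inhibition, meaning a higher number, is expected from the starting point of compound 1 at 2500 nM. The estimated change in this assay is a 3.2-fold higher number from compound 1 to compound 3 (0.51 log units; beyond the scatter). The estimate for compound 3 is 8000 nM, with an expected range of 2000 nM to 35000 nM.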

Compound 3, half-maximal inhibitory concentration: 400 nM
Beside the measured number, compound 3's estimate is 20-fold (1.30 log units) above it; measured number outside the range, below it.
By their numbers in this assay, from the lowest: compound 3; then compounds 2 and 1 (each within the scatter of the next).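

Replacing the phenyl on the amide-type nitrogen with hydrogen, the change from anilino to amino, gives a 6.3-fold lower number from compound 1 to compound 3 (0.80 log units; beyond the scatter) in this assay. For this pair, then, the phenyl is not needed for inhibition, and the compound with a plain amino group at this place is the stronger of the two. For the compounds shown here, the only earlier step, a 1.0-fold lower number from compound 1 to compound 2 (0.02 log units; within the scatter), stayed within the scatter, so this nitrogen is the first place where a change clearly moves the number, and nothing measured here explains why the number falls when the phenyl is lost.

The compounds shown leave open whether the gain belongs to the bare amino group itself or would survive a small group on that nitrogen, such as a methyl, an ethyl or a longer chain, or a non-aromatic ring such as cyclohexyl. Going by these compounds alone, they also leave open whether the methoxy still makes as little difference once the phenyl is gone, as its one measured step was read with the phenyl in place.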